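Trimethoxyphenyl in Place of Propyl: Expected Cytotoxicity

A few compounds are considered here, and "the series" means these few. Any claim that something is new, unique, unknown or untested is made for them only; others in the source may bear on it.

Compound 1 `CCCc1nnc(SCc2ccccc2)n1N1C(=O)c2ccccc2C1=O`: in a functional assay on HepG2 cells (Homo sapiens) for cytotoxicity, read by MTT assay, with a stated time of 48 h (a lower number here means a stronger inhibitor, a higher number a weaker inhibitor), compound 1 gives > 200000 nM, a limit.
Compound 2 `CCCc1nnc(SCC(=O)c2ccc(Cl)cc2)n1N1C(=O)c2ccccc2C1=O`: compound 2 gives > 200000 nM, a limit.
Compound 3 `C#CCSc1nnc(CCC)n1N1C(=O)c2ccccc2C1=O`: compound 3 gives > 200000 nM, a limit.

Compound 1 thus stands at the edge of what this assay reports, and so do its two neighbours: the limit of > 200000 nM in this assay, at which 3 of the 3 values shown sit. The change to compound 4 `COc1cc(-c2nnc(SCc3ccccc3)n2N2C(=O)c3ccccc3C2=O)cc(OC)c1OC` is 3,4,5-trimethoxyphenyl in place of propyl on an aromatic carbon. The measured steps a step that the two limits leave unreadable from compound 1 to compound 2, a step that the two limits leave unreadable from compound 1 to compound 3 and a step that the two limits leave unreadable from compound 2 to compound 3 all alter the group on the sulfur-bound chain carbon rather than the propyl, and none has a readable size. Going by the values given here, no measured step therefore speaks to the direction of the change in this assay. Compound 4 is expected to give 200000 nM, with a range from 60000 nM to 400000 nM, most likely reported once more as a limit. The expected step of a number no higher from compound 1 to compound 4 (the limit leaves the size open) is accordingly none beyond the scatter.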

Compound 4, half-maximal inhibitory concentration: > 200000 nM
Compound 4 was reported as a limit (the forecaster's own chance of this, stated with the estimate: 70%); the middle value sits exactly at the limit.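

Compound 1 and compound 4 are both reported only as limits, so the step from propyl to 3,4,5-trimethoxyphenyl has no readable size: the limit of > 200000 nM in this assay, at which 4 of the 4 values shown sit.

The compounds shown leave open what change, if any, would bring a readable value in this assay.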